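The compounds below may be only part of what the source reports. "The series", "measured", "known", "first", "only" and "open" are said of these compounds alone.

Measured in an in vivo ADME assay on the whole organism for pharmacokinetics, with Rattus norvegicus as the target; on this read-out lower numbers stand for a shorter-lived compound and higher numbers for a longer-lived compound:
- Compound 1 `COc1cc(C#N)c(NC(=O)c2sccc2S(=O)(=O)Nc2onc(C)c2Cl)c(OC)c1OC`: < 1 h
- Compound 2 `Cc1cc(C)c(NC(=O)c2sccc2S(=O)(=O)Nc2onc(C)c2Cl)c(C)c1C#N`: 1.8 h
- Compound 3 `COc1c(C)cc(C)c(CC(=O)c2sccc2S(=O)(=O)Nc2onc(C)c2Cl)c1C`: 3.86 h

The entry for compound 1 is a limit. Of the two actual numbers, compound 3 at 3.86 h holds the higher, and its gap to compound 2 at 1.8 h lies beyond the usual scatter.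

Compound 4 `Cc1cc(C)c(CC(=O)c2sccc2S(=O)(=O)Nc2onc(C)c2Cl)c(C)c1O` differs from compound 3 in one place: hydrogen in place of methyl on an oxygen on an aromatic ring, so methoxy becomes hydroxy. Among the measured compounds shown here, no measured pair shows this change, so the expectation in this assay is a judgement: a shortening of about the size of the usual scatter. The expected change is a 1.9-fold lower number from compound 3 to compound 4 (0.29 log units; within the scatter). For compound 4 the estimated value is 2 h, with an expected range of 0.8 h to 4.5 h.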

Compound 4, half-life in the Rattus norvegicus assay: 3.9 h
The estimate for compound 4 lay 2.0-fold (0.29 log units) below the measured number; measured number inside the range.
By their numbers in the Rattus norvegicus assay, from the lowest: compound 2; then compounds 3 and 4 (each within the scatter of the next). At a limit, below all of these: compound 1.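

In the Rattus norvegicus assay compound 3 gives 3.86 h and compound 4 gives 3.9 h. In the Rattus norvegicus assay, hydrogen in place of methyl on an oxygen on an aromatic ring gives a 1.0-fold higher number from compound 3 to compound 4 (0.00 log units; within the scatter), so methoxy and hydroxy are not told apart here. Among the compounds shown here, the earlier compounds offered no comparison in one place, and this is the first to show that this methyl can be replaced without the half-life moving beyond the scatter. In a physicochemical assay for solubility, in phosphate buffer, at pH 7.4 (on this read-out higher numbers stand for higher solubility and lower numbers for lower solubility), compound 3 stands as "not determined" (no result reported) and compound 4 as "not determined" (no result reported), so no comparison can be read there. Nothing available bears on the reason for this result.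

The compounds shown leave open whether an ethoxy group or an amine in the same place would give a similar half-life.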